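Chain-Extended Amine in a Cyclopropanecarboxamide Series

This account rests on a few compounds, and the source may have more. Where it says the series, first, only, none or still open, it means among the compounds named here.

Three compounds sharing one cyclopropanecarboxamide core have been run in a functional assay for agonist activity at G protein-coupled receptor 88 (Homo sapiens), read by HTRF and cAMP accumulation; on this read-out higher numbers stand for an effect only at larger amounts of compound and lower numbers for an effect already at smaller amounts. Compound 1 `CC(C)C[C@@H](N)CN(C(=O)[C@@H]1C[C@H]1c1ccccc1)c1ccc(-c2ccccc2)cc1` gives 1.8 nM, and compound 2 `CN[C@@H](CC(C)C)CN(C(=O)[C@@H]1C[C@H]1c1ccccc1)c1ccc(-c2ccccc2)cc1` gives 2 nM; the difference between them, a 1.1-fold higher number from compound 1 to compound 2 (0.05 log units; within the scatter), lies within the scatter. Compound 3 `CO[C@H](C)[C@H](N)CN(C(=O)[C@@H]1C[C@H]1c1ccccc1)c1ccc(-c2ccccc2)cc1` gives 0.68 nM, the lowest number of the three, with a 2.6-fold lower number from compound 1 to compound 3 (0.42 log units; beyond the scatter) and a 2.9-fold lower number from compound 2 to compound 3 (0.47 log units; beyond the scatter) both beyond the scatter, though modest in size.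

The next compound, compound 4 `CC(C)C[C@H](N)CCN(C(=O)[C@@H]1C[C@H]1c1ccccc1)c1ccc(-c2ccccc2)cc1`, is not yet measured. Against compound 3 the change is 2-amino-4-methylpentyl in place of 1-amino-2-methoxypropyl on a saturated chain carbon bound to an amide-type nitrogen: the same difference, cut one bond further out, reads as 2-amino-3-methoxybutyl to 3-amino-5-methylhexyl. The measured step that bears most directly on it is a 2.6-fold lower number from compound 1 to compound 3 (0.42 log units; beyond the scatter), which runs the other way: leaving 1-amino-2-methoxypropyl for a branched amino-alkyl chain cost a modest amount. Among the measured compounds shown here, no measured step in this assay addresses the rearranged 2-amino-4-methylpentyl chain itself, so that part is open.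

He therefore expects a modest rise in number, a 7.4-fold higher number from compound 3 to compound 4 (0.87 log units; beyond the scatter), placing compound 4 at an estimated 5 nM in this assay, with a range from 1.5 nM to 20 nM.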

Compound 4, half-maximal effective concentration: 3 nM
The estimate for compound 4 lay 1.7-fold (0.22 log units) above the measured number; the range from low to high includes it.
By their numbers in this assay, from the lowest: compound 3; then compounds 1, 2 and 4 (each within the scatter of the next).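

Within this assay, the longer 2-amino-4-methylpentyl chain cannot be told apart from the shorter amino-alkyl chains on this saturated chain carbon bound to an amide-type nitrogen: the comparison with 1-amino-3-methylbutyl gives a 1.7-fold higher number from compound 1 to compound 4 (0.22 log units; within the scatter), and the comparison with 3-methyl-1-(methylamino)butyl gives a 1.5-fold higher number from compound 2 to compound 4 (0.18 log units; within the scatter). The 1-amino-2-methoxypropyl chain, by contrast, stands apart from this new chain as well, with a 4.4-fold higher number from compound 3 to compound 4 (0.64 log units; beyond the scatter), so compound 3 now lies beyond the scatter from all three other compounds, while compounds 1, 2 and 4 form a group with no order among them. Nothing available here explains why the chain of compound 3 gives the lowest number.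

The compounds shown leave open whether a methoxy group carried on the longer 2-amino-4-methylpentyl chain would bring its number down to that of compound 3, and whether a hydroxyl group in place of the methoxy group would keep that number. They also leave open how a methylamine on the longer chain, the opposite configuration at its single defined stereocentre, or a chain longer still would read in this assay.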